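Swapping one aromatic group on compound 2

A few compounds are considered here, and "the series" means these few. Any claim that something is new, unique, unknown or untested is made for them only; others in the source may bear on it.

Compound 1 `COc1ccc([C@@H]2C/C(=N/O)c3cc(CC=C(C)C)c(OC)cc3O2)cc1`: 45%
Compound 2 `COc1ccc([C@@H]2C/C(=N/OCc3cn(-c4cccc(CO)c4)nn3)c3cc(CC=C(C)C)c(OC)cc3O2)cc1`: 34%

In a functional assay on PC-3 cells (Homo sapiens) for inhibition, read by sulforhodamine B assay, with a stated time of 48 h, tested at 50 uM (a higher number here means more inhibition of growth at the concentration tested, a lower number less inhibition of growth), compound 2 gives 34%, the lower of the two numbers, and its gap to compound 1 lies beyond the usual scatter. Compound 3 `COc1ccc([C@@H]2C/C(=N/OCc3cn(-c4cccnc4Cl)nn3)c3cc(CC=C(C)C)c(OC)cc3O2)cc1` has 2-chloropyridin-3-yl in place of 3-(hydroxymethyl)phenyl on an aromatic nitrogen. Going by the values given here, no measured pair shows what this swap does, so only a modest expectation is possible. The expected change is a step of a number 3 percentage points higher from compound 2 to compound 3 (within the scatter), with none beyond the scatter. Compound 3 is estimated at 37%, within an expected range of 22% to 52%.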

Compound 3, percent growth inhibition at one concentration: 44%
Compound 3: middle estimate off by 7 percentage points, on the low side; the measured number falls inside the stated range.
By their numbers in this assay, from the lowest: compounds 2, 3 and 1 (each within the scatter of the next, the first and the last beyond it).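

In this assay, replacing 3-(hydroxymethyl)phenyl with 2-chloropyridin-3-yl on the aromatic nitrogen gives a number 10 percentage points higher from compound 2 to compound 3 (within the scatter), so this position accepts a quite different aromatic group without a clear change. The swap also removes the group's hydrogen-bond donor, and the reading stays within the scatter. No available evidence bears on this result.

The compounds shown do not separate the effects of the ring nitrogen, the chlorine and the lost hydroxymethyl. They also leave open how a phenyl ring carrying an amine or a carboxylic acid would read here.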